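Swapping the azole substituent on the pyridazine-bearing core

This account rests on a few compounds, and the source may have more. Where it says the series, first, only, none or still open, it means among the compounds named here.

Going by the values given here, compound 1 `OCc1nnc(-c2ccc(N3CCC(Oc4ccccc4C(F)(F)F)CC3)nn2)s1` is the stronger of the two compounds measured so far. Among the compounds with values here, in an assay on microsomes from liver for inhibition of acyl-CoA desaturase 1 (Rattus norvegicus) (a higher number here means a weaker inhibitor, a lower number a stronger inhibitor), compound 1 gives 3.2 nM, whereas compound 2 `FC(F)(F)c1ccc(OC2CCN(c3ccc(-n4ccnc4)nn3)CC2)cc1` gives 371 nM; the gap between these two values lies well beyond the scatter, and compound 2 differs from compound 1 in more than one place, so the two values show only that the shared core of compound 1 can carry widely different potencies.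

Compound 3 `CC(C)Cc1nnc(-c2ccc(N3CCC(Oc4ccccc4C(F)(F)F)CC3)nn2)o1` has not yet been measured. Compared with compound 1, it carries one change: 5-isobutyl-1,3,4-oxadiazol-2-yl in place of 5-(hydroxymethyl)-1,3,4-thiadiazol-2-yl on an aromatic carbon. The hydrogen-bond donor of the 5-(hydroxymethyl)-1,3,4-thiadiazol-2-yl is lost, and a 5-isobutyl-1,3,4-oxadiazol-2-yl with more heavy atoms takes its place on the aromatic carbon para to a large group.

Within the data shown here, with no step between measured compounds to lean on, the expectation for this change is a modest weakening in this assay, possibly within the scatter. For compound 3 the expected step is a 3.8-fold higher number from compound 1 to compound 3 (0.57 log units; beyond the scatter). Compound 3 is estimated to give 12 nM in this assay, with a range from 2 nM to 80 nM.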

Compound 3, half-maximal inhibitory concentration: 15 nM
For compound 3 the middle estimate is 1.3-fold (0.10 log units) below the measured one, and the stated range covers the measured number.
By their numbers in this assay, from the lowest: compound 1; then compound 3; then compound 2.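

In this assay, going by these compounds alone, the exchange of 5-(hydroxymethyl)-1,3,4-thiadiazol-2-yl for 5-isobutyl-1,3,4-oxadiazol-2-yl gives a 4.7-fold higher number from compound 1 to compound 3 (0.67 log units; beyond the scatter), the first step in the set that can be read at this place on the shared core, and it is a modest one, although it lies beyond the scatter. It shows that this aromatic carbon, para to a large group, can carry a different azole with a branched chain, more heavy atoms and no hydrogen-bond donor, at the cost of only part of the potency of compound 1. The compounds offer no measurement that accounts for this step.

The change replaces the ring sulfur with oxygen and the hydroxymethyl with isobutyl in a single step, so the compounds shown leave open how much of the rise belongs to the ring and how much to the chain, a question that 5-(hydroxymethyl)-1,3,4-oxadiazol-2-yl or 5-isobutyl-1,3,4-thiadiazol-2-yl would address. They also leave open how this position would respond to an amine or a carboxylic acid on the azole in place of these chains.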